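A few compounds are considered here, and "the series" means these few. Any claim that something is new, unique, unknown or untested is made for them only; others in the source may bear on it.

Measured compounds:
Compound 1 `COc1ccc(C2CC(c3ccc(Cl)cc3)=NN2c2ccc(-c3ccccc3)nn2)c(OC)c1`: in a functional assay on MCF7 cells (Homo sapiens) for antiproliferative activity, read by MTT assay, with a stated time of 24 h (on this read-out higher numbers stand for weaker inhibition and lower numbers for stronger inhibition), compound 1 gives > 100000 nM, which is a limit of the assay and not a number.
Compound 2 `COc1cc(C2CC(c3ccc(Cl)cc3)=NN2c2ccc(-c3ccccc3)nn2)cc(OC)c1OC`: in this assay compound 2 gives 100000 nM.
Compound 3 `COc1ccc(C2=NN(c3ccc(-c4ccccc4)nn3)C(c3ccc(OC)cc3OC)C2)cc1`: in this assay compound 3 gives 100000 nM.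

Compound 2 differs from compound 1 by 3,4,5-trimethoxyphenyl in place of 2,4-dimethoxyphenyl on a saturated ring carbon. The step of a number no higher from compound 1 to compound 2 (the limit leaves the size open) has no readable size because compound 1 sits at the limit of > 100000 nM in this assay, at which 1 of the 3 values shown sits. Compound 3 differs from compound 1 by methoxy in place of chloro on an aromatic carbon. The step of a number no higher from compound 1 to compound 3 (the limit leaves the size open) is likewise left open in size because compound 1 sits at the limit of > 100000 nM in this assay, at which 1 of the 3 values shown sits. Compound 2 and compound 3 stand level at the digits given.

Compound 4 `COc1ccc(C2=NN(c3ccc(-c4ccccc4)nn3)C(c3cc(OC)c(OC)c(OC)c3)C2)cc1` is not yet measured. It differs from compound 3 by 3,4,5-trimethoxyphenyl in place of 2,4-dimethoxyphenyl on a saturated ring carbon, the same kind of change as from compound 1 to compound 2, though there the saturated ring carbon lies two ring bonds from the ring atom that bears a 4-chlorophenyl group, whereas in compound 3 it lies two ring bonds from the ring atom that bears a 4-methoxyphenyl group. Since the earlier step left no readable size and compound 3 gives 100000 nM, the step of no change at the digits printed from compound 3 to compound 4 (within the scatter) is expected to be small. Compound 4 is expected to give about 100000 nM in this assay, estimated between 50000 nM and 200000 nM, and a limit rather than a number is considered likely.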

Compound 4, half-maximal inhibitory concentration: 100000 nM
The estimate for compound 4 equals the measured number at the digits printed, within the range that was stated.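

In this assay, 3,4,5-trimethoxyphenyl in place of 2,4-dimethoxyphenyl gives no change at the digits printed from compound 3 to compound 4 (within the scatter), and methoxy in place of chloro on an aromatic carbon gives no change at the digits printed from compound 2 to compound 4 (within the scatter). Both changes therefore show no readable effect on the core where they can be sized, while the matching steps that start from compound 1 cannot be read in size, so the comparison for the trimethoxyphenyl change stays unresolved: the same change on two cores in this assay, a number no higher (the limit leaves the size open) from compound 1 to compound 2 and no change at the digits printed (within the scatter) from compound 3 to compound 4; the limit leaves it open whether they differ The methoxy change stands the same way, so the series shows neither that a change carries over unaltered from one core to another nor that it fails to: the same change on two cores in this assay, a number no higher (the limit leaves the size open) from compound 1 to compound 3 and no change at the digits printed (within the scatter) from compound 2 to compound 4; the limit leaves it open whether they differ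

The compounds shown leave open whether any group other than methoxy or chloro on these phenyl rings moves the read-out in this assay away from the level of compound 2, compound 3 and compound 4. An amine or a carboxylic acid on either ring, or a longer chain in place of a methoxy group, would bear on that question.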